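This account rests on a few compounds, and the source may have more. Where it says the series, first, only, none or still open, it means among the compounds named here.

Compound 1 `Cc1c(Nc2nc(N)c3c(C#N)c(N4CCC[C@H]4C)n(C)c3n2)cnn1C` in an assay on isolated protein for binding affinity to Leucine-rich repeat serine/threonine-protein kinase 2 (Homo sapiens), read by TR-FRET and LanthaScreen, with a stated time of 2 h (on this read-out higher numbers stand for weaker inhibition and lower numbers for stronger inhibition), gives 2 nM.
Compound 2 `CN(C)c1c(C#N)c2c(N)ncnc2n1C` in this assay gives 111 nM.
Compound 3 `Cn1c(NCc2ccccc2)c(C#N)c2c(N)ncnc21` in this assay gives 423 nM.

Of the three numbers measured in this assay, compound 2 holds the second highest. Compound 3 gives a higher number, and the gap between the two lies beyond the usual scatter of repeated measurements. Compound 1 gives a far lower number, and that gap lies well beyond the scatter as well.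

Compound 4 `C[C@H]1CCCN1c1c(C#N)c2c(N)ncnc2n1C` has not yet been measured. It differs from compound 2 in one place: 2-methylpyrrolidin-1-yl in place of dimethylamino on an aromatic carbon. The same 2-methylpyrrolidin-1-yl group is present in compound 1, although compound 1 also carries a different substituent elsewhere on the shared core, so the two changes cannot be separated from the measured numbers alone.

Because compound 1, which bears this group, gives 2 nM, the exchange is expected to move the number in this assay downward, toward stronger inhibition, by a moderate step that should exceed the scatter. The step from compound 2 to compound 4 is estimated as a 3.2-fold lower number from compound 2 to compound 4 (0.50 log units; beyond the scatter). Compound 4 is therefore expected to give about 35 nM in this assay, with a likely range from 10 nM to 120 nM.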

Compound 4, inhibition constant: 136 nM
Beside the measured number, compound 4's estimate is 3.9-fold (0.59 log units) below it; the whole stated range lies below it.
By their numbers in this assay, from the lowest: compound 1; then compounds 2 and 4 (each within the scatter of the next); then compound 3.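

In this assay, 2-methylpyrrolidin-1-yl in place of dimethylamino on this aromatic carbon gives a 1.2-fold higher number from compound 2 to compound 4 (0.09 log units; within the scatter), so on this read-out the two groups cannot be told apart at this position, even though one brings a five-membered non-aromatic ring and a defined stereocentre. This pair also separates the two differences that compound 1 had left joined: with 2-methylpyrrolidin-1-yl held in place, compound 4 gives 136 nM and compound 1 gives 2 nM, so the low number of compound 1 goes with its other substituent on the shared core and does not appear with 2-methylpyrrolidin-1-yl alone. The data offer no measured explanation for why this exchange leaves the number within the scatter.

Going by these compounds, whether the step stays this small when the other substituent of compound 1 is present on the shared core remains open. Also open, on these data alone, is whether a different amine at this position, such as pyrrolidin-1-yl without the methyl group, piperidin-1-yl or morpholin-4-yl, or the opposite configuration at the stereocentre, would separate from dimethylamino in this assay.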